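Para substituent series on the shared core: cytotoxicity notes

The source may report more compounds than this note shows. Statements on the series, on what has been measured and on what is new or still open speak of the compounds shown alone.

Measured compounds in an ADME assay on HEL cells (Homo sapiens) for cytotoxicity, read by cell counting, with a stated time of 3 days; on this read-out lower numbers stand for higher toxicity in this test and higher numbers for lower toxicity in this test:
- compound 1 `O=c1[nH]c(=O)n([C@H]2C[C@H](O)[C@@H](CO)O2)cc1-c1cn(-c2ccccc2)nn1`: 270000 nM
- compound 2 `CC(C)(C)c1ccc(-n2cc(-c3cn([C@H]4C[C@H](O)[C@@H](CO)O4)c(=O)[nH]c3=O)nn2)cc1`: 12400 nM
- compound 3 `O=c1[nH]c(=O)n([C@H]2C[C@H](O)[C@@H](CO)O2)cc1-c1cn(-c2ccc(Br)cc2)nn1`: 1000 nM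

Compound 3 gives the lowest number of the three. Its nearest neighbour is compound 2, a step of a 12-fold lower number from compound 2 to compound 3 (1.09 log units; beyond the scatter); the furthest is compound 1, a step of a 270-fold lower number from compound 1 to compound 3 (2.43 log units; beyond the scatter). Both steps end at compound 3 and both are beyond the scatter, so compound 3 stands apart on this read-out.

Compound 4 `O=c1[nH]c(=O)n([C@H]2C[C@H](O)[C@@H](CO)O2)cc1-c1cn(-c2ccc(Oc3ccccc3)cc2)nn1` differs from compound 3 in one place: phenoxy in place of bromo on an aromatic carbon. The group that enters brings an additional six-membered aromatic ring of carbon only and one hydrogen-bond acceptor, on the same carbon, para to a large group.

For the measured compounds named here, no measured step covers a phenoxy group, so the bearing steps are indirect. The step of a 22-fold lower number from compound 1 to compound 2 (1.34 log units; beyond the scatter) and the step of a 270-fold lower number from compound 1 to compound 3 (2.43 log units; beyond the scatter) show that putting a group on this carbon has lowered the number each time, and by a large amount. Whether a phenoxy group continues that movement or reverses it cannot be read from these three compounds; compound 2 and compound 3 already differ by a 12-fold lower number from compound 2 to compound 3 (1.09 log units; beyond the scatter) between two substituents on the same carbon.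

Compound 4 is therefore estimated at 1500 nM, with a range from 300 nM to 8000 nM. This amounts to an expected step of a 1.5-fold higher number from compound 3 to compound 4 (0.18 log units; within the scatter) in this assay, not beyond the scatter.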

Compound 4, half-maximal cytotoxic concentration: 450 nM
Estimate against measurement, compound 4: 3.3-fold (0.52 log units) above; measured number inside the range.
By their numbers in this assay, from the lowest: compound 4; then compound 3; then compound 2; then compound 1.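

In this assay, phenoxy in place of bromo does not reverse the downward movement at this carbon: the step is a 2.2-fold lower number from compound 3 to compound 4 (0.35 log units; beyond the scatter) and is modest, yet it is beyond the scatter, so the bulkier group with its added six-membered aromatic ring still lowers the number. The same group gives a 28-fold lower number from compound 2 to compound 4 (1.44 log units; beyond the scatter) and a 600-fold lower number from compound 1 to compound 4 (2.78 log units; beyond the scatter) so all three groups on this carbon now sit well under hydrogen, and heavy-atom count does not set the order, since bromo with 1 heavy atom and phenoxy with 7 heavy atoms both lie under tert-butyl. Nothing among the available data accounts for this order.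

Open is whether the lowering holds for an amine, a carboxylic acid or a longer alkyl chain at this carbon, since the three groups shown span only a halogen, a branched alkyl group and an aryl ether. Also open, going by these compounds, is whether the oxygen of phenoxy matters, a question that a benzyl or a directly attached phenyl group at the same carbon would address.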